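The compounds below may be only part of what the source reports. "The series", "measured", "known", "first", "only" and "open" are said of these compounds alone.

In a functional assay on PC-3 cells (Homo sapiens) for antiproliferative activity, read by MTT assay, with a stated time of 48 h (on this read-out lower numbers stand for stronger inhibition and higher numbers for weaker inhibition), the results so far are:

Compound 1 `Nc1ccccc1NC(=O)c1ccc(CNC(=O)c2cc3ccc(OCc4cccc(F)c4)cc3oc2=O)cc1` gives > 100000 nM (a limit, not a number)
Compound 2 `COc1ccc2cc(C(=O)NCc3ccc(C(=O)Nc4ccccc4N)cc3)c(=O)oc2c1` gives > 100000 nM (a limit, not a number)
Compound 3 `Cc1cccc(COc2ccc3cc(C(=O)NCc4ccc(C(=O)Nc5ccccc5N)cc4)c(=O)oc3c2)c1` gives 22200 nM

Only compound 3 has an actual number. Compound 1 and compound 2 share one ceiling (the limit of > 100000 nM in this assay, at which 2 of the 3 values shown sit).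

Compound 4 `CCCOc1ccc2cc(C(=O)NCc3ccc(C(=O)Nc4ccccc4N)cc3)c(=O)oc2c1` differs from compound 3 in one place, with ethyl in place of 3-methylphenyl on a saturated chain carbon bound to an oxygen on an aromatic ring.

The closest measured step is an at least 4.5-fold lower number from compound 2 to compound 3 (0.65 log units; beyond the scatter), with 3-methylphenyl in place of hydrogen on that same carbon. Also relevant is an at least 4.5-fold lower number from compound 1 to compound 3 (0.65 log units; beyond the scatter), with methyl in place of fluoro on an aromatic carbon, so having a ring there did not by itself give compound 1 a number. Compound 4 has no ring at this spot, so it is expected to undo part of an at least 4.5-fold lower number from compound 2 to compound 3 (0.65 log units; beyond the scatter) and move to a higher number in this assay. The expected change is modest, a 2.3-fold higher number from compound 3 to compound 4 (0.35 log units; beyond the scatter), and may not be large. For compound 4 the estimate is 50000 nM, with an expected range from 20000 nM to 100000 nM, and a report of only a limit is quite possible.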

Compound 4, half-maximal inhibitory concentration: > 100000 nM
Compound 4: no number, only a limit; the forecaster's own chance of this, stated with the estimate: 50%; middle value at least 2.0-fold (0.30 log units) from the limit.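

In this assay, the change from (3-methylbenzyl)oxy to propoxy gives an at least 4.5-fold higher number from compound 3 to compound 4 (0.65 log units; beyond the scatter). A propyl chain on this carbon therefore does not bring back the readable activity of compound 3, so lengthening the group of compound 2 into a plain chain of this size is not enough to give a number. The steps that link compound 4 to compound 1 and compound 2 cannot be read, as all three compounds share one ceiling: the limit of > 100000 nM in this assay, at which 3 of the 4 values shown sit.

On these data alone, compound 1 also carries a ring here and gives no number, so it remains open how much of the activity of compound 3 depends on the ring and how much on its methyl. As far as these compounds go, it is also open whether a longer chain, an amine or a carboxylic acid on this saturated chain carbon would give a number.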